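From trifluorophenyl to benzyl in a growth-inhibition series

A few compounds are considered here, and "the series" means these few. Any claim that something is new, unique, unknown or untested is made for them only; others in the source may bear on it.

Of the compounds shown here, two have been measured in a functional assay on PANC-1 cells (Homo sapiens) for inhibition, read by sulforhodamine B assay, with a stated time of 48 h (a lower number here means a stronger inhibitor of growth, a higher number a weaker inhibitor of growth), so far. Compound 1 (`O=C(O)c1cn(C2CC2)c2cc(N3CCN(C(=O)CCSc4nnnn4-c4ccc(Br)cc4)CC3)c(F)cc2c1=O`) gives 60 nM there and compound 2 (`CCn1cc(C(=O)O)c(=O)c2cnc(N3CCN(C(=O)CCSc4nnnn4-c4ccc(F)c(F)c4F)CC3)nc21`) gives 60 nM as well. Compound 2 therefore stands level with compound 1 within the scatter, although the two structures differ in more than one place.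

Compound 3 (`CCn1cc(C(=O)O)c(=O)c2cnc(N3CCN(C(=O)CCSc4nnnn4Cc4ccccc4)CC3)nc21`) departs from compound 2 at a single place (benzyl in place of 2,3,4-trifluorophenyl on an aromatic nitrogen), with benzyl in place of 2,3,4-trifluorophenyl on an aromatic nitrogen of a five-membered aromatic ring with 4 nitrogen. For the measured compounds named here, no measured pair shows a change of this kind, so the data give no direct guide to its size. Compound 1 at 60 nM and compound 2 at 60 nM both carry halogen on the carbon ring at this place, whereas compound 3 carries none. A modest step toward weaker growth inhibition in this assay is therefore expected, though one that may not clear the scatter. The estimated change is a 2.2-fold higher number from compound 2 to compound 3 (0.34 log units; beyond the scatter) on this reasoning. For compound 3 the estimated value is 130 nM with an expected range from 35 nM to 500 nM in this assay.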

Compound 3, concentration for 50% growth inhibition: 60 nM
Estimate against measurement, compound 3: 2.2-fold (0.34 log units) above; low and high end bracket the measured number.
By their numbers in this assay, from the lowest: compounds 1, 2 and 3 (each within the scatter of the next).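

In this assay, putting benzyl in place of 2,3,4-trifluorophenyl on an aromatic nitrogen of the five-membered aromatic ring with 4 nitrogen gives no change at the digits printed from compound 2 to compound 3 (within the scatter). For the compounds shown here, this is the first pair that differs in one place, and it shows directly that, on the core of compound 2, the fluorine-bearing ring can give way to a benzyl group carrying no halogen while the growth-inhibition number stays level, so halogen on the carbon ring at this place is not required to hold that number in this pair. No measurement is available that would explain why the number holds across this change.

What the compounds shown leave open is how far this tolerance extends, for instance to a small methyl group, a longer chain such as phenylethyl, or a group carrying an amine or a carboxylic acid on the same nitrogen. Going by these compounds, compound 1 differs from the others in more than one place, so its steps cannot be read, and whether the same change would behave alike on its core also stays open.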